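Dibromothiophene Replacing Methylthiophene in a Sulfonylurea Series

This account rests on a few compounds, and the source may have more. Where it says the series, first, only, none or still open, it means among the compounds named here.

Three sulfonylureas that share the core of compound 1 `O=C(Nc1ccc(Cl)cc1)NS(=O)(=O)c1ccc(Cl)s1` have been tested in a functional assay on the whole organism (6C3HED cells, Mus musculus) for inhibition, at a dose of 150 mg/kg by the oral route; on this read-out lower numbers stand for less inhibition and higher numbers for more inhibition at the one dose given (going by the name of the read-out). Compound 1 gives 58%. Compound 2 `CSc1ccc(S(=O)(=O)NC(=O)Nc2ccc(Cl)cc2)s1` gives 29%, and compound 3 `Cc1ccsc1S(=O)(=O)NC(=O)Nc1ccc(Cl)cc1` gives 17%, the lowest of the three numbers, set apart from both others by steps beyond the scatter. Between the measured compounds, the step of a number 29 percentage points lower from compound 1 to compound 2 (beyond the scatter) goes with methylsulfanyl in place of chloro on an aromatic carbon, the step of a number 41 percentage points lower from compound 1 to compound 3 (beyond the scatter) with 3-methylthiophen-2-yl in place of 5-chlorothiophen-2-yl on a sulfonyl sulfur, and the step of a number 12 percentage points lower from compound 2 to compound 3 (beyond the scatter) with 3-methylthiophen-2-yl in place of 5-(methylsulfanyl)thiophen-2-yl on the same sulfur.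

Compound 4 `O=C(Nc1ccc(Cl)cc1)NS(=O)(=O)c1cc(Br)c(Br)s1` differs from compound 3 in one place: 4,5-dibromothiophen-2-yl in place of 3-methylthiophen-2-yl on a sulfonyl sulfur

The two steps that alter the group on the sulfonyl sulfur bear on this change. The larger of them, a number 41 percentage points lower from compound 1 to compound 3 (beyond the scatter), shows that leaving a chloro-bearing thiophen-2-yl group for the 3-methyl one cost much inhibition in this assay. Compound 4 brings back a halogen-bearing thiophen-2-yl group, so a rise toward the number of compound 1, which gives 58%, is expected. The expected step is a number 28 percentage points higher from compound 3 to compound 4 (beyond the scatter). Compound 4 is therefore estimated at 45%, with a range from 20% to 70%.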

Compound 4, a percentage reported as inhibition, in the whole organism at one dose (the size of the read-out at that dose, not a potency): 25%
Compound 4: the middle estimate sits 20 percentage points above what was measured; the range from low to high includes it.
By their numbers in this assay, from the lowest: compounds 3, 4 and 2 (each within the scatter of the next, the first and the last beyond it); then compound 1.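

In this assay, a halogen-bearing thiophen-2-yl group does not by itself hold the level of the 5-chlorothiophen-2-yl group: putting 4,5-dibromothiophen-2-yl on the sulfonyl sulfur gives a number 33 percentage points lower from compound 1 to compound 4 (beyond the scatter). The same group cannot be told apart from the 3-methylthiophen-2-yl group, with a number 8 percentage points higher from compound 3 to compound 4 (within the scatter), or from the 5-(methylsulfanyl)thiophen-2-yl group, with a number 4 percentage points lower from compound 2 to compound 4 (within the scatter), even though those two groups are themselves separated by a number 12 percentage points lower from compound 2 to compound 3 (beyond the scatter). Compound 1 thus remains the only one of the four whose steps to all the others lie beyond the scatter, so at this position the presence of halogen does not mark out the higher number, as compound 4 shows.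

No measurement at hand gives a reason for this result. The compounds shown do not separate the kind of halogen from the number of halogens, a question on which a 5-bromothiophen-2-yl or a 4,5-dichlorothiophen-2-yl group on the same sulfur would bear, and they leave open how a thiophen-2-yl group carrying an amine or a carboxylic acid would read.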